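Cyclising the urea substituent: compound 2 to compound 3

The compounds below may be only part of what the source reports. "The series", "measured", "known", "first", "only" and "open" are said of these compounds alone.

Measured compounds:
compound 1 `Cc1cc(C(=O)N2CCCCc3ccccc32)ccc1CNC(=O)Nc1c(F)cccc1F`: 0%
compound 2 `Cc1cc(C(=O)N2CCCCc3ccccc32)ccc1CNC(=O)NCC(=O)N(C)C`: 82%

In a functional assay on the whole organism (urine, strain Long-Evans) for inhibition, with Rattus norvegicus as the target, with a stated time of 1 h, at a dose of 1 mg/kg by the oral route (a lower number here means less inhibition, a higher number more inhibition at the dose given (going by the name of the read-out)), compound 1 gives 0%, and compound 2 gives 82%. Going by the values given here, the single step between them, a number 82 percentage points higher from compound 1 to compound 2 (beyond the scatter), puts compound 2 at the top of the two numbers, with compound 1 far behind it.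

Compound 3 `Cc1cc(C(=O)N2CCCCc3ccccc32)ccc1CNC(=O)N1C[C@H](O)C[C@H]1C(=O)N(C)C` has not yet been measured. It differs from compound 2 in one place: 2-(dimethylcarbamoyl)-4-hydroxypyrrolidin-1-yl in place of ((dimethylcarbamoyl)methyl)amino on a carbonyl carbon. The dimethylcarbamoyl group stays, the open chain becomes part of a five-membered ring, a hydroxyl is added and the amide hydrogen of the urea is lost.

Among the compounds with values here, only one measured step exists, and it bears on this change indirectly: it shows that a dimethylcarbamoyl-bearing substituent on the urea goes with high inhibition in this assay, whereas an aryl group there goes with none. Nothing measured tells how the ring or the hydroxyl will act. Because compound 2 reaches 82% with the same dimethylcarbamoyl group, compound 3 is expected to keep a good part of that inhibition, with a downward step of a number 22 percentage points lower from compound 2 to compound 3 (beyond the scatter) expected. Compound 3 is estimated at 60%, within a range of 20% to 90%.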

Compound 3, a percentage reported as inhibition, in the whole organism at one dose (the size of the read-out at that dose, not a potency): 68%
For compound 3 the middle estimate is 8 percentage points below the measured one; the measured number falls inside the stated range.
By their numbers in this assay, from the lowest: compound 1; then compound 3; then compound 2.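

In this assay, the urea carbonyl carbon accepts a ring-bearing substituent with most of the inhibition kept: 2-(dimethylcarbamoyl)-4-hydroxypyrrolidin-1-yl in place of ((dimethylcarbamoyl)methyl)amino gives a number 14 percentage points lower from compound 2 to compound 3 (beyond the scatter), a modest but real loss, so the open chain is not required for high inhibition at this dose. The same substituent in place of (2,6-difluorophenyl)amino gives a number 68 percentage points higher from compound 1 to compound 3 (beyond the scatter), which means that two different dimethylcarbamoyl-bearing substituents now stand far above the aryl one, and none of the three compounds goes against this. The change from compound 2 to compound 3 brings in the ring, the hydroxyl, the two defined stereocentres and the loss of the amide hydrogen all at once, and nothing available explains the lower number or assigns it to any one of these.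

Still open, on these data alone, is what the hydroxyl adds, which 2-(dimethylcarbamoyl)pyrrolidin-1-yl on the same carbonyl carbon would show, and how the opposite arrangement at the stereocentres would read. As far as these compounds go, it is also open whether a carboxylic acid or a methyl ester could stand in place of the dimethylcarbamoyl group.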